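This account rests on a few compounds, and the source may have more. Where it says the series, first, only, none or still open, it means among the compounds named here.

Compound 1 `CNc1nc(N)nc2c1ncn2/C=C1/CC1(CO)CO`: 67000 nM
Compound 2 `CCCCCOc1nc(N)nc2c1ncn2/C=C1/CC1(CO)CO`: > 20000 nM (a limit)

Among the compounds with values here, in an ADME assay on BCBL1 cells (Homo sapiens) for cytotoxicity, with a stated time of 7 days (on this read-out higher numbers stand for lower toxicity in this test and lower numbers for higher toxicity in this test), compound 1 gives 67000 nM, the only true number so far. Compound 2 has only a limit of the assay, > 20000 nM, and so no exact standing. the limit of > 20000 nM in this assay, at which 1 of the 2 values shown sits, is what the data offer on this point.

Compound 3 `Nc1nc(SC2CCCC2)c2ncn(/C=C3/CC3(CO)CO)c2n1` has cyclopentylsulfanyl in place of pentyloxy on an aromatic carbon, next to the ring nitrogen: cyclopentylsulfanyl in place of pentyloxy on an aromatic carbon. Within the data shown here, the one measured step, a step that the limit leaves unreadable from compound 1 to compound 2, gives no size to carry over, so no direction is expected in this assay. The expectation therefore leans on compound 1 with its 67000 nM. The estimated step is a step that the limit leaves unreadable from compound 2 to compound 3. For compound 3 the expected value is 40000 nM, with an estimated range from 12000 nM to 100000 nM.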

Compound 3, half-maximal cytotoxic concentration: > 20000 nM
Compound 3: only a limit was reported; the forecaster's own chance of this, stated with the estimate: 55%; the middle value is on the limit's open side.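

In this assay compound 3 gives > 20000 nM, which is a limit of the assay and not a number. Within the data shown here, no step linking compound 3 to compound 1 or compound 2 can be read. The compounds shown leave open how compound 2 and compound 3 compare with each other or with compound 1.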